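The source may report more compounds than this note shows. Statements on the series, on what has been measured and on what is new or still open speak of the compounds shown alone.

In a functional assay, with a stated time of 30 min (on this read-out lower numbers stand for stronger inhibition and higher numbers for weaker inhibition), compound 1 (`O=C(/C=C/c1ccc(O)c(O)c1)CC(=O)/C=C/c1cc(O)ccc1O`) gives 60000 nM and compound 2 (`O=C(/C=C/c1cc(O)ccc1O)CC(=O)/C=C/c1cc(O)ccc1O`) gives 57000 nM while compound 3 (`O=C(/C=C/c1ccc(O)c(O)c1)/C=C/c1ccccc1O`) gives 62000 nM so that compound 3 stands level with the other two, with no gap beyond the scatter among the three. Compound 4 (`O=C(/C=C/c1ccc(O)cc1)/C=C/c1ccc(O)c(O)c1`) has the same atoms as compound 3, joined differently, and the difference is this one (4-hydroxyphenyl in place of 2-hydroxyphenyl on a double-bonded chain carbon bound to a double-bonded chain carbon): 4-hydroxyphenyl in place of 2-hydroxyphenyl on a double-bonded chain carbon bound to a double-bonded chain carbon. Among the measured compounds shown here, the one measured step of a similar kind puts 2,5-dihydroxyphenyl in place of 3,4-dihydroxyphenyl at that same kind of place, and it comes to a 1.1-fold lower number from compound 1 to compound 2 (0.02 log units; within the scatter) in this assay and so leaves the number within the scatter. For the measured compounds named here, this is only a single step, and no measured compound carries 4-hydroxyphenyl, so the evidence is thin. On this basis no step beyond the scatter is expected in this assay in either direction. The expected change is a 1.1-fold lower number from compound 3 to compound 4 (0.05 log units; within the scatter) and no more than that. The estimate for compound 4 is 55000 nM with an expected range from 25000 nM to 120000 nM around it.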

Compound 4, half-maximal inhibitory concentration in the functional assay: 24000 nM
Compound 4: middle estimate off by 2.3-fold (0.36 log units), on the high side; measured number below the stated range.
By their numbers in the functional assay, from the lowest: compound 4; then compounds 2, 1 and 3 (each within the scatter of the next).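

In the functional assay, 4-hydroxyphenyl in place of 2-hydroxyphenyl on a double-bonded chain carbon bound to a double-bonded chain carbon gives a 2.6-fold lower number from compound 3 to compound 4 (0.41 log units; beyond the scatter), whereas the earlier step between 3,4-dihydroxyphenyl and 2,5-dihydroxyphenyl, a 1.1-fold lower number from compound 1 to compound 2 (0.02 log units; within the scatter), showed no such separation. Among the compounds shown here, this is the first step to pass the scatter, and it comes from two groups with the same atoms, joined differently, so the number at this place can move without any change in the group's heavy atoms or its hydrogen-bond donors and acceptors. In a physicochemical assay for solubility, using the shake flask method, with a stated time of 12 h (a lower number here means a less soluble compound, a higher number a more soluble compound), compound 3 gives 111000 nM and compound 4 gives 19000 nM. The gain in inhibition does not come alone, since the same change also leaves compound 4 less soluble than compound 3 in the physicochemical assay: the measured solubility of compound 3, 111000 nM, and of compound 4, 19000 nM, a 5.8-fold lower number (0.77 log units; beyond the scatter)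

What the compounds leave open is whether an amine or a carboxylic acid on the phenyl ring at this place would keep the stronger inhibition in the functional assay without the loss in the physicochemical assay. From the compounds shown here alone, this change also rests on a single pair, so whether it would carry over to the longer chain of compound 1 and compound 2 remains unknown.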